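A few compounds are considered here, and "the series" means these few. Any claim that something is new, unique, unknown or untested is made for them only; others in the source may bear on it.

Compound 1 `CC/C(=C(/c1ccc(/C=C/C(=O)O)cc1)c1cc2ccccc2[nH]1)c1cccc(OC(F)(F)F)c1` is the reference point of this pair of notes. In a functional assay on MCF7 cells (Homo sapiens) for inhibition (on this read-out higher numbers stand for weaker inhibition and lower numbers for stronger inhibition), compound 1 gives 282 nM, the highest of the two numbers at hand. Within the data shown here, the nearest neighbour is compound 2 `CC/C(=C(/c1ccc(/C=C/C(=O)O)cc1)c1cc2ccccc2[nH]1)c1ccc(Cl)cc1Cl`, which in this assay gives 11 nM; the one measured step, a 26-fold lower number from compound 1 to compound 2 (1.41 log units; beyond the scatter), is large and well beyond the scatter.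

Compound 3 `CC/C(=C(/c1ccc(/C=C/C(=O)O)cc1)c1cc2ccccc2[nH]1)c1ccc(C(F)(F)F)cc1Cl` is still to be measured in this assay. Its change from compound 1 is 2-chloro-4-(trifluoromethyl)phenyl in place of 3-(trifluoromethoxy)phenyl on a double-bonded chain carbon bound to a double-bonded chain carbon and a saturated chain carbon The group entering in compound 3 resembles the 2,4-dichlorophenyl that enters in compound 2, the trifluoromethyl standing where compound 2 carries its second chlorine; the chlorine of the 2-chloro-4-(trifluoromethyl)phenyl is common to both. Among the measured compounds shown here, the only step that bears on the question is therefore a 26-fold lower number from compound 1 to compound 2 (1.41 log units; beyond the scatter), and on that single precedent a decrease of comparable size is expected for compound 3, namely a 14-fold lower number from compound 1 to compound 3 (1.15 log units; beyond the scatter). With one precedent the range is kept wide. For compound 3 the estimate in this assay is 20 nM, expected to fall between 6 nM and 70 nM.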

Compound 3, half-maximal inhibitory concentration: 27 nM
Compound 3: middle estimate off by 1.4-fold (0.13 log units), on the low side, within the range that was stated.
By their numbers in this assay, from the lowest: compound 2; then compound 3; then compound 1.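

In this assay, the drop in the number at this double-bonded chain carbon is no longer tied to 2,4-dichlorophenyl alone: a 10-fold lower number from compound 1 to compound 3 (1.02 log units; beyond the scatter), so 2-chloro-4-(trifluoromethyl)phenyl also gives a large step away from 3-(trifluoromethoxy)phenyl. The two groups that lower the number are not interchangeable, however: with trifluoromethyl in place of chloro on an aromatic carbon there is a 2.5-fold higher number from compound 2 to compound 3 (0.39 log units; beyond the scatter), a modest step that is still beyond the scatter and smaller than either step from compound 1. Nothing among the data offers an explanation for either step.

Since 3-(trifluoromethoxy)phenyl differs from both entering groups in more than one feature, these compounds cannot show how much of the large steps goes with the chlorine of the entering groups and how much with the loss of the trifluoromethoxy group. Also open, going by these compounds, is how a nitrile or a methoxy group would compare with chloro and trifluoromethyl on that aromatic carbon, and how an unsubstituted phenyl would compare at the double-bonded chain carbon.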